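Hydroxy in place of nitro on the shared core

The source may hold more compounds than are shown below. What is called first, only, known or untested is meant among the compounds shown, and "the series" means these compounds.

In a functional assay on HepG2 cells (Homo sapiens) for cytotoxicity, read by MTT assay, with a stated time of 48 h (a higher number here means a weaker inhibitor, a lower number a stronger inhibitor), compound 1 (`COc1ccc2c(c1)nc(/C=C/C(=O)/C=C/c1ccc(O)c(OC)c1)n2C`) gives 3800 nM and compound 2 (`COc1cc(/C=C/C(=O)/C=C/c2nc3cc([N+](=O)[O-])ccc3n2C)ccc1O`) gives 3700 nM with no gap beyond the scatter, so compound 2 stands level with compound 1. Compound 3 (`COc1cc(/C=C/C(=O)/C=C/c2nc3cc(O)ccc3n2C)ccc1O`) carries hydroxy in place of nitro on an aromatic carbon. For the measured compounds named here, the only measured step at this place, a 1.0-fold lower number from compound 1 to compound 2 (0.01 log units; within the scatter) for nitro in place of methoxy on an aromatic carbon, lies within the scatter. Hydroxy itself is untested here, so this expectation rests on thin evidence. The expected step (a 1.0-fold higher number from compound 2 to compound 3 (0.01 log units; within the scatter)) stays within the scatter. Compound 3 is estimated at 3800 nM (range 1500 nM to 9000 nM).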

Compound 3, half-maximal inhibitory concentration: 3600 nM
Estimate against measurement, compound 3: 1.1-fold (0.02 log units) above; measured number inside the range.
By their numbers in this assay, from the lowest: compounds 3, 2 and 1 (each within the scatter of the next).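

In this assay this aromatic carbon now holds methoxy, nitro and hydroxy without separation: hydroxy in place of nitro gives a 1.0-fold lower number from compound 2 to compound 3 (0.01 log units; within the scatter) and hydrogen in place of methyl on the oxygen gives a 1.1-fold lower number from compound 1 to compound 3 (0.02 log units; within the scatter) within the scatter. A group with a hydrogen-bond donor therefore reads level with the two groups without one at this position. No supporting evidence accounts for this flat result.

As far as these compounds go, whether an amine or a carboxylic acid here would also stay level remains open, as does the reading for a longer chain on the oxygen.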